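The source may hold more compounds than are shown below. What is called first, only, known or untested is meant among the compounds shown, and "the series" means these compounds.

Values from an ADME assay on HepG2 cells (Homo sapiens) for cytotoxicity, read by luminescence, with a stated time of 72 h (on this read-out higher numbers stand for an effect only at larger amounts of compound and lower numbers for an effect already at smaller amounts), so far:
Compound 1 `CCOC(=O)c1c(-c2cccc(C)c2)[nH]c2cc(OC)ccc2c1=O` gives > 21500 nM as a limit.
Compound 2 `CCOC(=O)c1c(-c2cccc(OC(F)(F)F)c2)[nH]c2cc(OC)ccc2c1=O` gives > 21500 nM as a limit.
Compound 3 `CCOC(=O)c1c(-c2cccc(Cl)c2)[nH]c2cc(OC)ccc2c1=O` gives > 21500 nM as a limit.

Compound 3 gives no number and stands only at the limit of > 21500 nM in this assay, at which 3 of the 3 values shown sit, and nothing more exact. The change to compound 4 `CCOC(=O)c1c(-c2cccc([N+](=O)[O-])c2)[nH]c2cc(OC)ccc2c1=O` is nitro in place of chloro on an aromatic carbon and puts nitro in place of chloro on an aromatic carbon, meta to a large group. Because a step that the two limits leave unreadable from compound 1 to compound 2 and a step that the two limits leave unreadable from compound 1 to compound 3 and a step that the two limits leave unreadable from compound 2 to compound 3 give no readable size for swaps on an aromatic carbon, no step beyond the usual scatter is expected in this assay and no direction either. The expected outcome is a step that the limit leaves unreadable from compound 3 to compound 4 and no clear shift. Compound 4 is estimated at 30000 nM within an expected range from 15000 nM to 60000 nM and will probably be reported as a limit again.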

Compound 4, half-maximal effective concentration: > 21500 nM
Compound 4 gave a limit, no number; the forecaster's own chance of this, stated with the estimate: 85%; the middle value is on the limit's open side.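

In this assay, going by these compounds alone, compound 4, like compound 1, compound 2 and compound 3, gives only a limit, so no step among them can be read: the limit of > 21500 nM in this assay, at which 4 of the 4 values shown sit. These compounds leave open the concentration at which any of them would show an effect in this assay.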